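Nitro for methoxy on the anilino ring of compound 1

The source may hold more compounds than are shown below. What is called first, only, known or untested is meant among the compounds shown, and "the series" means these compounds.

Three compounds of the series have numbers in an assay on cell membranes for displacement of a labelled ligand from Neuronal acetylcholine receptor; alpha4/beta2 (Rattus norvegicus); a lower number here means a stronger inhibitor, a higher number a weaker inhibitor. Compound 1 `COc1ccc(Nc2cncc(N3CC4CC(C3)N4)c2)cc1` gives 0.0598 nM and stands lowest of the three. Its nearest neighbour in this assay is compound 3 `O=[N+]([O-])c1ccc(Nc2ccc(N3CC4CC(C3)N4)cn2)cc1`, which carries a nitro group on a different core and gives 1.76 nM; that gap is beyond the scatter. Furthest away is compound 2 `CN(c1ccccc1)c1ccc(N2CC3CC(C2)N3)nn1`, which gives 1430 nM in this assay, again well beyond the scatter. No two of the measured compounds differ in only one place, so no single-change step can be read from them; what the numbers show is that compound 1 is the strongest inhibitor among the three.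

Compound 4 `O=[N+]([O-])c1ccc(Nc2cncc(N3CC4CC(C3)N4)c2)cc1` is not yet measured in this assay. It differs from compound 1 by nitro in place of methoxy on an aromatic carbon. Compound 3 shows that a nitro-bearing anilino group on a related core gives 1.76 nM, so the change is not expected to abolish inhibition. The step from the methoxy to the nitro analogue is expected to be modest, towards a higher number, close to the edge of the scatter: the expected step is a 2.5-fold higher number from compound 1 to compound 4 (0.40 log units; beyond the scatter). Compound 4 is therefore estimated at 0.15 nM in this assay, with a range from 0.03 nM to 0.8 nM.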

Compound 4, inhibition constant: 0.0225 nM
Compound 4: the middle estimate sits 6.7-fold (0.82 log units) above what was measured; the measured number lies below the stated range.
By their numbers in this assay, from the lowest: compound 4; then compound 1; then compound 3; then compound 2.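

In this assay, nitro in place of methoxy at this position, para to a large group, gives a 2.7-fold lower number from compound 1 to compound 4 (0.42 log units; beyond the scatter). For the compounds shown here, this is the first single-change step, and it shows that on the core of compound 1 this position accepts nitro as well as methoxy with no loss of inhibition, the number moving towards stronger inhibition. Nitro also carries more heavy atoms and more hydrogen-bond acceptors than methoxy, but a single pair cannot separate these differences, and no measured property is available to account for the step.

The compounds shown leave open how an amine, a carboxylic acid or a bare hydrogen at this position would compare with methoxy and nitro, and two groups alone define no trend. Also open is whether the same change would give a step of similar size and direction on another core, the only single-change pair shown being the one on the core of compound 1.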